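Hydrazone Amides and Macrophage Toxicity: the Methoxy Analogue

The source may report more compounds than this note shows. Statements on the series, on what has been measured and on what is new or still open speak of the compounds shown alone.

Measured so far:
compound 1, `CC(/C=N/Nc1ccc([N+](=O)[O-])cc1)=N\NC(=O)c1ccc(O)cc1`: in an ADME assay on J774 cells (Mus musculus, strain BALB/c) for cytotoxicity, read by resazurin assay, with a stated time of 72 h (on this read-out lower numbers stand for higher toxicity in this test and higher numbers for lower toxicity in this test), compound 1 gives 51000 nM.
compound 2, `CC(/C=N/Nc1ccc([N+](=O)[O-])cc1)=N\NC(=O)c1ccccc1C`: in this assay compound 2 gives > 100000 nM, a limit of the assay rather than a number.

Compound 2 stands at the top of the two numbers shown, but only as a limit (the limit of > 100000 nM in this assay, at which 1 of the 2 values shown sits), so its true toxicity is not pinned down. Among the compounds with values here, the one measured step, an at least 1.9-fold higher number from compound 1 to compound 2 (0.29 log units; that floor lies within the scatter), is itself only a floor and sits within the usual scatter, so it gives no firm direction for further changes on the carbonyl carbon.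

Compound 3, `COc1ccc(C(=O)N/N=C(C)/C=N/Nc2ccc([N+](=O)[O-])cc2)cc1`, has not yet been measured. Its change from compound 2 is 4-methoxyphenyl in place of 2-methylphenyl on a carbonyl carbon. Within the data shown here, the only step that bears on it is the one from compound 1 to compound 2, and it did not reach beyond the scatter. Compound 3 is therefore expected to show no step beyond the scatter in this assay, and a limit is again a real possibility. Compound 3 is estimated at 90000 nM, with a range from 35000 nM to 250000 nM. The expected step is an at least 1.1-fold lower number from compound 2 to compound 3 (0.04 log units; that floor lies within the scatter).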

Compound 3, half-maximal cytotoxic concentration: > 100000 nM
Compound 3 ended at the assay's limit; the forecaster's own chance of this, stated with the estimate: 45%; middle value at least 1.1-fold (0.04 log units) away from the limit.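

In this assay, compound 3 also ends at a limit rather than a number, so two different groups on this carbonyl carbon, 2-methylphenyl and 4-methoxyphenyl, now share that result, and the step between them cannot be read because both values are limits: the limit of > 100000 nM in this assay, at which 2 of the 3 values shown sit.

The new comparison with compound 1 isolates a smaller change, methyl in place of hydrogen on the oxygen on the aromatic ring, and it gives an at least 1.9-fold higher number from compound 1 to compound 3 (0.29 log units; that floor lies within the scatter). Within the data shown here, this floor, like the one for compound 2, does not establish a real difference from compound 1, so the hydroxyl hydrogen cannot yet be tied to the toxicity seen, but a second replacement of the 4-hydroxyphenyl group has now reached the limit of the test.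

On these data alone, the true values of compound 2 and compound 3 remain unknown, so these two compounds cannot be ranked against each other, and the size of any gain over compound 1 remains unsettled. The compounds shown also leave open how this test would respond to an amine or a carboxylic acid on the aromatic ring, or to a longer chain in place of the methyl on the oxygen.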